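Growing the Sulfonyl Group in an Orexin Agonist Series

The source may report more compounds than this note shows. Statements on the series, on what has been measured and on what is new or still open speak of the compounds shown alone.

The account concerns three compounds measured in a functional assay on CHO-K1 cells for agonist activity at Orexin receptor type 2 (Homo sapiens), read by FLIPR and calcium flux (on this read-out lower numbers stand for an effect already at smaller amounts and higher numbers for an effect only at larger amounts of compound), and a fourth awaiting measurement. Compound 1 `CCS(=O)(=O)NC1CCCN(C(C)=O)C1COC1CCC(C(C)C)CC1`, drawn without configurations, gives 570 nM. Compound 2 `CCS(=O)(=O)N[C@H]1CCCN(C(C)=O)[C@H]1CO[C@H]1CC[C@@H](C(C)C)CC1` gives 270 nM, and the step of a 2.1-fold lower number from compound 1 to compound 2 (0.32 log units; beyond the scatter) accompanies (the fact that one of compounds 1 and 2 is drawn with a defined configuration and the other without, at the place where they differ). Compound 3 `CC(=O)N1CCC[C@H](NS(C)(=O)=O)[C@@H]1CO[C@H]1CC[C@@H](C(C)C)CC1` gives 330 nM; among the three numbers it stands second highest, within the scatter of compound 2 and also within the scatter of compound 1. The step of a 1.2-fold higher number from compound 2 to compound 3 (0.09 log units; within the scatter) shows that shortening the chain on the sulfonyl sulfur did not move the number beyond the scatter.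

Compound 4 `CC(=O)N1CCC[C@H](NS(=O)(=O)C(C)C)[C@@H]1CO[C@H]1CC[C@@H](C(C)C)CC1` differs from compound 3 by isopropyl in place of methyl on a sulfonyl sulfur. For the measured compounds named here, the only measured step that bears on this place is the one from compound 2 to compound 3, and it was within the scatter. The author therefore expects no step beyond the scatter in this assay, with at most a slight drift toward a lower number. The expected step is a 1.2-fold lower number from compound 3 to compound 4 (0.07 log units; within the scatter). Compound 4 is estimated at 280 nM, within a range from 120 nM to 650 nM.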

Compound 4, half-maximal effective concentration: 940 nM
For compound 4 the middle estimate is 3.4-fold (0.53 log units) below the measured one; measured number above the stated range.
By their numbers in this assay, from the lowest: compounds 2, 3, 1 and 4 (each within the scatter of the next, the first and the last beyond it).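

In this assay this position on the sulfonyl sulfur turns out not to be indifferent to its substituent. Methyl in compound 3 and ethyl in compound 2 lie within the scatter of each other, yet isopropyl in place of methyl brings a 2.8-fold higher number from compound 3 to compound 4 (0.45 log units; beyond the scatter), and the same compound stands further from the ethyl compound, with a 3.5-fold higher number from compound 2 to compound 4 (0.54 log units; beyond the scatter). The flat response seen on shortening the chain therefore does not extend to isopropyl, and nothing in the data shown accounts for this step.

As far as these compounds go, what a cyclopropyl, tert-butyl or phenyl group on the sulfonyl sulfur would give remains open. So does whether isopropyl in this place would give a step of similar size on a core other than the one shared here.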